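The compounds below may be only part of what the source reports. "The series", "measured", "known", "first", "only" and "open" are said of these compounds alone.

Measured so far in a functional assay on Huh-7 cells (Homo sapiens) for inhibition, read by MTT assay, with a stated time of 48 h; on this read-out lower numbers stand for stronger inhibition and higher numbers for weaker inhibition:
- Compound 1, `COc1ccc(CNC(=O)/C=C/c2coc3cc(O)ccc3c2=O)cc1`, gives 8430 nM.
- Compound 2, `COc1cccc(NC(=O)/C=C/c2coc3cc(OC)ccc3c2=O)c1`, gives 11100 nM.
- Compound 3, `COc1ccc(NC(=O)/C=C/c2coc3cc(O)ccc3c2=O)cc1`, gives only a limit of the assay, > 100000 nM.

Among the two compounds that return a number in this assay, compound 2 gives the higher one, but its gap to compound 1 lies within the usual scatter, so the two cannot be told apart. Compound 3 sits at the limit described in the limit of > 100000 nM in this assay, at which 1 of the 3 values shown sits, and that limit is all that is known of it.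

The next compound in this series is compound 4, `COc1ccc2c(=O)c(/C=C/C(=O)Nc3ccc(Cl)cc3)coc2c1`. It is built from compound 2 by a single change: 4-chlorophenyl in place of 3-methoxyphenyl on an amide-type nitrogen. Among the compounds with values here, no pair of measured compounds differs in only this way, so there is no measured step to lean on. With the two numbered values lying within scatter of each other and the third being a limit, the expectation for this change is a step of no clear size in either direction. The step from compound 2 to compound 4 is therefore estimated as a 1.1-fold lower number from compound 2 to compound 4 (0.05 log units; within the scatter). On that basis compound 4 is expected to give about 10000 nM in this assay, with a plausible range from 3000 nM to 40000 nM.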

Compound 4, half-maximal inhibitory concentration: 37100 nM
For compound 4 the middle estimate is 3.7-fold (0.57 log units) below the measured one, within the range that was stated.
By their numbers in this assay, from the lowest: compounds 1 and 2 (each within the scatter of the next); then compound 4. At a limit, above all of these: compound 3.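

In this assay, the group on this amide-type nitrogen turns out to matter: 4-chlorophenyl in place of 3-methoxyphenyl brings a 3.3-fold higher number from compound 2 to compound 4 (0.52 log units; beyond the scatter), which means weaker inhibition by a modest step that lies beyond the usual scatter. Within the data shown here, this is the first measured step between two compounds that differ in one place, so it gives the first direct reading of this position. Both groups contain one six-membered aromatic ring of carbon only, so the ring stays and only what it carries and where it carries it differ, but nothing measured here explains why the number goes up.

On these data alone, what stays open is whether the step comes from the exchange of methoxy for chlorine or from the different place on the ring, and a 3-chlorophenyl group on this nitrogen, with the rest of compound 2 kept, would separate the two. As far as these compounds go, it is also open how this position would respond to something quite different from these two groups, such as a phenyl ring carrying a carboxylic acid or an amine.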